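The source may hold more compounds than are shown below. What is called first, only, known or untested is meant among the compounds shown, and "the series" means these compounds.

Measured compounds:

Compound 1, `CNC(=O)c1cc(C(=O)NC)c2c(c1)[C@](C)(c1ccccc1)CO2` — 3.4
Compound 2, `CNC(=O)c1cc(C(=O)NCCC[C@H]2OC[C@H](N)CO2)cc2c1OC[C@H]2c1ccccc1` — 2.6
Compound 3, `CNC(=O)c1cc(C(N)=O)cc2c1OC[C@H]2c1ccccc1` — 2.7

All three were measured in a physicochemical assay for lipophilicity, at pH 7.4; on this read-out higher numbers stand for higher lipophilicity and lower numbers for lower lipophilicity. Compound 1 stands highest of the three; compound 3 lies below it by a gap beyond the scatter, and compound 2 lies lower still, also beyond the scatter.

The compound still to be measured is compound 4, `CNC(=O)c1cc(C(=O)N[C@H]2[C@@H]3C[C@@H](O)C[C@@H]32)cc2c1OC[C@@]2(C)c1ccccc1`. Relative to compound 1 the change is a group of 7 heavy atoms (6 carbon, 1 oxygen; one three-membered non-aromatic ring of carbon only, one five-membered non-aromatic ring of carbon only) in place of one carbon atom, on an amide-type nitrogen.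

Going by the values given here, only one measured step touches the same position. From compound 2 to compound 3, a group on the amide-type nitrogen was exchanged for a hydrogen atom, and this assay moved by a number 0.10 log units higher from compound 2 to compound 3 (within the scatter). That group, however, held a nitrogen and two oxygens in a six-membered ring, whereas the group entering compound 4 consists of carbon rings with a single oxygen as the one hydrogen-bond donor and acceptor. The measured step therefore gives only a loose guide, and the expectation rests mainly on the change itself.

A modest rise in this assay is expected, of about a number 0.40 log units higher from compound 1 to compound 4 (beyond the scatter) from compound 1. Compound 4 is thus estimated at 3.8, with a likely range from 3.2 to 4.4.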

Compound 4, distribution coefficient: 3.3
Compound 4: the middle estimate sits 0.50 log units above what was measured; the range from low to high includes it.
By their numbers in this assay, from the lowest: compounds 2 and 3 (each within the scatter of the next); then compounds 4 and 1 (each within the scatter of the next).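

At the amide-type nitrogen, a methyl gave way to a far larger group of 7 heavy atoms, with a three-membered and a five-membered carbon ring, and this assay shows a number 0.10 log units lower from compound 1 to compound 4 (within the scatter), so this pair cannot be told apart on this read-out. Going by these compounds alone, the only earlier step at this nitrogen, a number 0.10 log units higher from compound 2 to compound 3 (within the scatter), exchanged a different group for a hydrogen atom on a different core, so two quite unlike exchanges at this place now both stay within the scatter. No measured information is available here to explain this result.

The compounds shown leave open how much the oxygen of the entering group and its carbon rings each contribute, since no partner of compound 4 with the same rings but without that oxygen appears among them, and a single arrangement of its 4 defined stereocentres says nothing about the others. They also leave open whether this assay would stay as close to compound 1 with a carboxylic acid or a tert-butyl group on this amide-type nitrogen.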